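A few compounds are considered here, and "the series" means these few. Any claim that something is new, unique, unknown or untested is made for them only; others in the source may bear on it.

Compound 1 `COc1cccc(/C=C/C(=O)c2c(OC)cc(OC)c(CC=C(C)C)c2O)c1` gives 49200 nM in an ADME assay on MCF7-DOX cells (Homo sapiens) for cytotoxicity, read by MTT assay, with a stated time of 48 h; a higher number here means a weaker inhibitor, a lower number a stronger inhibitor. Compound 2 `COc1cc(O)c(C(=O)/C=C/c2cccc(N3CCNCC3)c2)c(OC)c1` gives 99200 nM and compound 3 `COc1cc(O)c(C(=O)/C=C/c2cccc(N3CCN(C)CC3)c2)c(OC)c1` gives 62200 nM, so compound 1 stands within the scatter of both. Compound 4 `COc1cc(OC)c(C(=O)/C=C/c2cccc(Cl)c2)c(O)c1CC=C(C)C` keeps the core of compound 1 and carries chloro in place of methoxy on an aromatic carbon, meta to a large group (chloro in place of methoxy on an aromatic carbon). Among the compounds with values here, the only measured step, a 1.6-fold lower number from compound 2 to compound 3 (0.20 log units; within the scatter), is a methyl in place of hydrogen on an amine nitrogen in a ring. Within the data shown here, it lies within the scatter and involves a different change, and no measured pair tests 3-methoxyphenyl to 3-chlorophenyl. No shift beyond the scatter is therefore expected in this assay. The estimated step is a 1.1-fold lower number from compound 1 to compound 4 (0.04 log units; within the scatter). For compound 4 the expected value is 45000 nM, with an estimated range from 20000 nM to 95000 nM.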

Compound 4, half-maximal inhibitory concentration: 59500 nM
The estimate for compound 4 lay 1.3-fold (0.12 log units) below the measured number; the measured number falls inside the stated range.
By their numbers in this assay, from the lowest: compounds 1, 4, 3 and 2 (each within the scatter of the next).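

In this assay the swap from 3-methoxyphenyl to 3-chlorophenyl gives a 1.2-fold higher number from compound 1 to compound 4 (0.08 log units; within the scatter), so replacing methoxy with chloro at this aromatic carbon leaves the number within the scatter on the core of compound 1. Within the data shown here, the earlier compounds offered no measured step at this position, since their only step was on an amine nitrogen in a ring. Nothing at hand gives a reason for this result. From the compounds shown here alone, whether a carboxylic acid or a nitrile at this position would move the number beyond the scatter remains open.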